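The compounds below may be only part of what the source reports. "The series", "measured", "known", "first", "only" and "open" are said of these compounds alone.

In a functional assay on A549 cells (Homo sapiens), read by sulforhodamine B assay, with a stated time of 5 days (a lower number here means a stronger inhibitor of growth, a higher number a weaker inhibitor of growth), compound 1 `OC[C@H]1O[C@@H](n2cc(F)c3c(-c4ccccc4)ncnc32)[C@H](O)[C@@H]1O` gives > 10000 nM, which is a limit and not a number. Compound 2 `OC[C@H]1O[C@@H](n2cc(F)c3c(-c4c[nH]cn4)ncnc32)[C@H](O)[C@@H]1O` gives > 10000 nM, also a limit. Compound 1 thus stands at the limit of > 10000 nM in this assay, at which 2 of the 3 values shown sit. Compound 3 `OC[C@H]1O[C@@H](n2cc(F)c3c(-c4ccsc4)ncnc32)[C@H](O)[C@@H]1O` gives a measured 380 nM.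

Every measured step changes the aromatic group on the shared core. These are a step that the two limits leave unreadable from compound 1 to compound 2, then an at least 26-fold lower number from compound 1 to compound 3 (1.42 log units; beyond the scatter), and finally an at least 26-fold lower number from compound 2 to compound 3 (1.42 log units; beyond the scatter). The last two are large, and both end at the thiophen-3-yl of compound 3.

Compound 4 `OC[C@H]1O[C@@H](n2cc(Cl)c3c(-c4ccccc4)ncnc32)[C@H](O)[C@@H]1O` keeps the phenyl of compound 1 and changes only the halogen: chloro in place of fluoro on an aromatic carbon. That is chloro in place of fluoro on an aromatic carbon of the five-membered aromatic ring. Within the data shown here, no measured step covers this exchange, so the large steps give no direct size for it. In this assay no step beyond the scatter is expected, and a second limit is the likeliest report. The expected change is a number no higher from compound 1 to compound 4 (the limit leaves the size open). For compound 4 the estimate is 10000 nM, with an expected range of 3000 nM to 30000 nM.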

Compound 4, concentration for 50% growth inhibition: 2500 nM
Estimate against measurement, compound 4: 4.0-fold (0.60 log units) above; measured number outside the range, below it.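

Among these compounds, with the phenyl kept, the exchange of halogen alone gives an at least 4.0-fold lower number from compound 1 to compound 4 (0.60 log units; beyond the scatter) in this assay, so the carbon two ring bonds from the ring nitrogen also bears on growth inhibition, not only the aromatic group changed in the earlier steps. Compound 4 also shows that a phenyl group does not by itself hold a compound of this series at the limit. The size of the step remains open because the value of compound 1 is a limit, not a number: the limit of > 10000 nM in this assay, at which 2 of the 4 values shown sit.

Going by these compounds, whether chloro in place of fluoro gives a similar step with the thiophen-3-yl of compound 3 or the 1H-imidazol-4-yl of compound 2 stays open. The compounds shown also do not tell how bromo, a methyl group or a nitrile at this carbon would compare with chloro.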